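The source may hold more compounds than are shown below. What is called first, only, known or untested is meant among the compounds shown, and "the series" means these compounds.

Measured compounds:
compound 1 `O=C(NNC(=O)c1ccccc1Cl)c1ccc(NS(=O)(=O)c2cnc(O)nc2O)cc1`, 1900 nM
compound 2 `O=C(NNC(=O)c1cccc(Cl)c1)c1ccc(NS(=O)(=O)c2cnc(O)nc2O)cc1`, 2290 nM
compound 3 `O=C(NNC(=O)c1ccccc1Cl)c1cccc(NS(=O)(=O)c2cnc(O)nc2O)c1`, 3740 nM

All three values come from a functional assay on A549 cells (Homo sapiens) for antiproliferative activity, read by MTT assay, with a stated time of 24 h; on this read-out higher numbers stand for weaker inhibition and lower numbers for stronger inhibition. Compound 2 differs from compound 1 by 3-chlorophenyl in place of 2-chlorophenyl on a carbonyl carbon, and the step this made was a 1.2-fold higher number from compound 1 to compound 2 (0.08 log units; within the scatter). Compound 3 shares the same atoms as compound 1 joined differently; the difference between the two cores is not broken down here. Compound 4 `O=C(NNC(=O)c1cccc(NS(=O)(=O)c2cnc(O)nc2O)c1)c1cccc(Cl)c1` is not yet measured in this assay. It differs from compound 3 by 3-chlorophenyl in place of 2-chlorophenyl on a carbonyl carbon, the same change as from compound 1 to compound 2, at the same place. Because a 1.2-fold higher number from compound 1 to compound 2 (0.08 log units; within the scatter) stayed within scatter, the step in this assay is expected to be about a 1.2-fold higher number from compound 3 to compound 4 (0.07 log units; within the scatter). The estimate for compound 4 in this assay is 4400 nM, expected between 2200 nM and 9000 nM.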

Compound 4, half-maximal inhibitory concentration: 6000 nM
Compound 4: middle estimate off by 1.4-fold (0.13 log units), on the low side; measured number inside the range.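

In this assay, 3-chlorophenyl in place of 2-chlorophenyl on a carbonyl carbon gives a 1.6-fold higher number from compound 3 to compound 4 (0.21 log units; within the scatter), and this step can be set beside the one on the other core: the same change on two cores in this assay, a 1.2-fold higher number (0.08 log units; within the scatter) from compound 1 to compound 2 and a 1.6-fold higher number (0.21 log units; within the scatter) from compound 3 to compound 4, 1.3-fold (0.12 log units) apart, within the scatter of two such steps. Within these two pairs, the change carries from one core to the other with no difference that can be told from the scatter. Neither step is shown to be a real effect of the change on its core, and two cores say nothing about how the change would behave on a third.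

Going by these compounds, whether a methoxyphenyl or a longer alkyl chain on this carbonyl carbon would move the number beyond the scatter remains open. Also open, on these data alone, is whether the two cores would respond alike to such a group.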